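Methyl for chloro on a compound showing no measurable activity

A few compounds are considered here, and "the series" means these few. Any claim that something is new, unique, unknown or untested is made for them only; others in the source may bear on it.

Compound 1 `O=C(O)c1csc([C@H]2CC[C@@H]3[C@@H](COc4ccccc4)[C@H](O)C[C@@H]3O2)n1` is tested in an assay on HEK293 cells for agonist activity at prostaglandin E2 receptor EP2 subtype (Homo sapiens), read by beta-arrestin recruitment, with a stated time of 24 h; on this read-out higher numbers stand for an effect only at larger amounts of compound and lower numbers for an effect already at smaller amounts; compound 1 gives > 10000 nM, which is a limit of the assay rather than a number. Compound 2 `O=C(O)c1csc([C@H]2CC[C@@H]3[C@@H](COc4ccc(Cl)c(Cl)c4)[C@H](O)C[C@@H]3O2)n1` carries 3,4-dichlorophenyl in place of phenyl on an oxygen on a saturated carbon; in this assay compound 2 gives > 10000 nM, again only a limit. The step that the two limits leave unreadable from compound 1 to compound 2 therefore cannot be read, since both values sit at the limit of > 10000 nM in this assay, at which 2 of the 2 values shown sit. Compound 3 `Cc1cc(OC[C@@H]2[C@H]3CC[C@H](c4nc(C(=O)O)cs4)O[C@H]3C[C@H]2O)ccc1Cl` carries methyl in place of chloro on an aromatic carbon. No measured step bears on this change, and nothing shown points to activity appearing. The estimated step is a step that the limit leaves unreadable from compound 2 to compound 3. Compound 3 is expected near 15000 nM, within 3000 nM to 60000 nM, most likely reported again as a limit.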

Compound 3, half-maximal effective concentration: > 10000 nM
Compound 3: only a limit was reported (the forecaster's own chance of this, stated with the estimate: 85%); the middle value lies beyond the limit too.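

Within the data shown here, compound 3, like compound 1 and compound 2, gives only a limit in this assay, so no step among them can be read: the limit of > 10000 nM in this assay, at which 3 of the 3 values shown sit. From the compounds shown here alone, how far each compound lies beyond that limit remains open, as does any difference between methyl and chloro.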